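Replacing 4-Fluorophenyl with 2-Phenylethenyl on the Carbonyl

A few compounds are considered here, and "the series" means these few. Any claim that something is new, unique, unknown or untested is made for them only; others in the source may bear on it.

Compound 1 `CN1CCN(c2ccc(C3=NNC(c4ccc(N(C)C)cc4)C3)cc2)CC1` gives 2.4% in a functional assay on NCI-H1975 cells (Homo sapiens) for inhibition, read by sulforhodamine B assay, tested at 10 uM; a lower number here means less inhibition, a higher number more inhibition at the concentration tested (going by the name of the read-out).
Compound 2 `CC(=O)N1N=C(c2ccc(N3CCN(C)CC3)cc2)CC1c1ccc(N(C)C)cc1` gives -1.9%.
Compound 3 `CN1CCN(c2ccc(C3=NN(C(=O)c4ccc(F)cc4)C(c4ccc(N(C)C)cc4)C3)cc2)CC1` gives 32.2%.

Compound 3 stands highest of the three: the steps of a number 29.8 percentage points higher from compound 1 to compound 3 (beyond the scatter) and a number 34.1 percentage points higher from compound 2 to compound 3 (beyond the scatter) both lie beyond the scatter, while a number 4.3 percentage points lower from compound 1 to compound 2 (within the scatter) does not. Compound 4 `CN1CCN(c2ccc(C3=NN(C(=O)/C=C/c4ccccc4)C(c4ccc(N(C)C)cc4)C3)cc2)CC1` differs from compound 3 in one place: 2-phenylethenyl in place of 4-fluorophenyl on a carbonyl carbon. For the measured compounds named here, the only measured step at this carbonyl carbon is a number 34.1 percentage points higher from compound 2 to compound 3 (beyond the scatter), where 4-fluorophenyl took the place of methyl; here one group carrying a six-membered aromatic ring replaces another, so that step bears only loosely. Going by the values given here, with no closer precedent, the expectation is a change in this assay within the scatter, in either direction: a number 2.2 percentage points lower from compound 3 to compound 4 (within the scatter). Compound 4 is therefore estimated at 30%, between 10% and 50%.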

Compound 4, a percentage reported as inhibition, at one concentration (the size of the read-out at that concentration, not a potency): 81%
The estimate for compound 4 lay 51 percentage points below the measured number; the measured number lies above the stated range.
By their numbers in this assay, from the lowest: compounds 2 and 1 (each within the scatter of the next); then compound 3; then compound 4.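

In this assay, the group on this carbonyl carbon matters even when one group carrying a six-membered aromatic ring replaces another, since 2-phenylethenyl for 4-fluorophenyl gives a number 48.8 percentage points higher from compound 3 to compound 4 (beyond the scatter) beyond what compound 3 reached. Measured against methyl on the carbonyl carbon, the same group gives a number 82.9 percentage points higher from compound 2 to compound 4 (beyond the scatter) and measured against hydrogen on the ring nitrogen it gives a number 78.6 percentage points higher from compound 1 to compound 4 (beyond the scatter) as the overall gain. Nothing measured here explains this rise. The change adds a double bond and removes fluorine together, so their shares stay unseparated. The saturated 2-phenylethyl or the 2-(4-fluorophenyl)ethenyl group would pull them apart.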